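The compounds below may be only part of what the source reports. "The series", "measured", "known", "first", "only" and "open" are said of these compounds alone.

Of the compounds shown here, three that share one core have been tested in a functional assay on the whole organism (strain C57BL/6) for inhibition, with Mus musculus as the target, read by paw edema, with stated times of 1 h and 4 h, at a dose of 100 mg/kg by the oral route; a higher number here means more inhibition at the dose given (going by the name of the read-out), a lower number less inhibition. Compound 1 `COc1ccccc1NC(=O)CCc1nc(Cc2ccc(NC(C)=O)cc2)no1` gives 87.7% in this assay, compound 2 `CC(=O)Nc1ccc(Cc2noc(CCC(=O)Nc3ccccc3F)n2)cc1` gives 67.1%, and compound 3 `CC(=O)Nc1ccc(Cc2noc(CCC(=O)Nc3cccc(C)c3)n2)cc1` gives 16.4%. Compound 3 therefore stands lowest of the three: the drop a number 71.3 percentage points lower from compound 1 to compound 3 (beyond the scatter) and the drop a number 50.7 percentage points lower from compound 2 to compound 3 (beyond the scatter) both lie beyond the scatter, while the smaller drop a number 20.6 percentage points lower from compound 1 to compound 2 (beyond the scatter) shows that the two higher compounds also differ from each other. All three differ only in the group carried on the amide-type nitrogen.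

Compound 4 `CC(=O)Nc1ccc(Cc2noc(CCC(=O)NCc3ccccc3)n2)cc1` has not yet been measured. It differs from compound 3 in one place: benzyl in place of 3-methylphenyl on an amide-type nitrogen. The two steps that end at compound 3 bear on this change, because a number 71.3 percentage points lower from compound 1 to compound 3 (beyond the scatter) and a number 50.7 percentage points lower from compound 2 to compound 3 (beyond the scatter) both put 3-methylphenyl onto that nitrogen and both lowered inhibition sharply, so taking that group away again can be expected to recover part of the loss. Within the data shown here, no measured step involves benzyl, so the size of the recovery is uncertain. In this assay compound 4 is expected to show a rise a number 23.6 percentage points higher from compound 3 to compound 4 (beyond the scatter), giving an estimated 40% with a range from 10% to 75%.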

Compound 4, a percentage reported as inhibition, in the whole organism at one dose (the size of the read-out at that dose, not a potency): 76.7%
Compound 4: middle estimate off by 36.7 percentage points, on the low side; the measured number lies above the stated range.
By their numbers in this assay, from the lowest: compound 3; then compounds 2 and 4 (each within the scatter of the next); then compound 1.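

In this assay, the step of a number 60.3 percentage points higher from compound 3 to compound 4 (beyond the scatter) shows that a low reading does not follow from the atoms alone: benzyl and 3-methylphenyl have the same heavy atoms and the same counts, joined differently, yet they give very different results on this amide-type nitrogen. Benzyl is also not separated from 2-fluorophenyl, as the step of a number 9.6 percentage points higher from compound 2 to compound 4 (within the scatter) stays within the scatter, so a benzyl group is compatible with substantial inhibition at this position. Among these compounds, the step of a number 11 percentage points lower from compound 1 to compound 4 (beyond the scatter) is modest but beyond the scatter, leaving 2-methoxyphenyl ahead of benzyl and making 3-methylphenyl the only one of the four groups tied to a low reading.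

Nothing available explains why these two groups of identical composition behave so differently. From the compounds shown here alone, it remains open whether the low reading of compound 3 belongs to the methyl group itself or to where it sits on the ring, and how an unsubstituted phenyl, a 4-methylphenyl or a 2-phenylethyl group on the same nitrogen would read.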